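The source may report more compounds than this note shows. Statements on the series, on what has been measured and on what is new or still open speak of the compounds shown alone.

Measured so far in a functional assay on HCT-116 cells (Homo sapiens) for antiproliferative activity, read by MTT assay, with a stated time of 48 h; a lower number here means a stronger inhibitor, a higher number a weaker inhibitor:
compound 1, `COc1ncc(-c2ccc3nc(NC(C)=O)nn3c2)cc1NS(=O)(=O)c1ccc(Cl)cc1`, gives 740 nM
compound 2, `COc1ncc(-c2ccc3nc(NC(C)=O)nn3c2)cc1NS(=O)(=O)c1ccc(C)cc1`, gives 600 nM
compound 3, `COc1ncc(-c2ccn3nc(NC(C)=O)nc3c2)cc1NS(=O)(=O)c1ccc(Cl)cc1`, gives 1330 nM

Compound 1 and compound 2 share one core and differ only by methyl in place of chloro on an aromatic carbon. That change gave a 1.2-fold lower number from compound 1 to compound 2 (0.09 log units; within the scatter), so the two numbers cannot be told apart with confidence. Compound 3 carries the other core of the series; the difference between the two cores is not broken down here. Against compound 1 the number for compound 3 lies within the scatter, against compound 2 it lies beyond it.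

Compound 4, `COc1ncc(-c2ccn3nc(NC(C)=O)nc3c2)cc1NS(=O)(=O)c1ccc(C)cc1`, is not yet measured. Among the compounds with values here, it differs from compound 3 by methyl in place of chloro on an aromatic carbon, the same change, at the same place, as that from compound 1 to compound 2; only that one earlier step is available to judge it, and nothing shows how the second core responds to it. Compound 4 is therefore expected to sit close to compound 3, with a step of a 1.2-fold lower number from compound 3 to compound 4 (0.08 log units; within the scatter), because a 1.2-fold lower number from compound 1 to compound 2 (0.09 log units; within the scatter) was small. The estimate for compound 4 is 1100 nM, expected to fall between 600 nM and 2200 nM.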

Compound 4, half-maximal inhibitory concentration: 1380 nM
For compound 4 the middle estimate is 1.3-fold (0.10 log units) below the measured one, within the range that was stated.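

In this assay, methyl in place of chloro on the core of compound 3 gave a 1.0-fold higher number from compound 3 to compound 4 (0.02 log units; within the scatter), so the two numbers cannot be told apart. Set beside the earlier step on the core of compound 1, the change reads alike on both cores: the same change on two cores in this assay, a 1.2-fold lower number (0.09 log units; within the scatter) from compound 1 to compound 2 and a 1.0-fold higher number (0.02 log units; within the scatter) from compound 3 to compound 4, 1.3-fold (0.11 log units) apart, within the scatter of two such steps. This shows that going from 4-chlorophenyl to 4-methylphenyl left the number within the scatter on each of these two cores, but it rests on two pairs and a single change, and it does not show that any other change would carry from one core to the other in the same way.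

Open, as far as these compounds go, is how an amine or a carboxylic acid in place of chloro or methyl at this position would read on each core, and whether a step beyond the scatter, if one arose, would also carry across. Also open, from the compounds shown here alone, is how a longer chain at the same place would compare on the two cores.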